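A Methyl Added to the Acid-Bearing Ring

This account rests on a few compounds, and the source may have more. Where it says the series, first, only, none or still open, it means among the compounds named here.

Compound 1 `CN1C[C@@H](COc2ccc(C(=O)N(C)c3cccc(CC(=O)O)c3)cc2)Oc2ccccc21` gives 760 nM in an assay on CHO cells for displacement of a labelled ligand from prostaglandin D2 receptor (Mus musculus), read by scintillation counting, with a stated time of 60 min; on this read-out lower numbers stand for stronger inhibition and higher numbers for weaker inhibition.
Compound 2 `CN1C[C@@H](COc2ccc(C(=O)Nc3cccc(CC(=O)O)c3)c(Cl)c2)Oc2ccccc21` gives 16 nM in this assay.
Compound 3 `Cc1cc(OC[C@@H]2CN(C)c3ccccc3O2)ccc1C(=O)Nc1ccc(F)c(CC(=O)O)c1` gives 15 nM in this assay.

Of the compounds shown here, three sharing one core have been tested in this assay. Compound 2 stands second highest of the three numbers; its nearest neighbour is compound 3, whose number lies within the scatter of it, and its furthest is compound 1, whose number lies well beyond the scatter. Compound 1 differs from the others in more than one place, so no single change can be read from that gap.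

The next compound, compound 4 `Cc1cc(CC(=O)O)cc(NC(=O)c2ccc(OC[C@@H]3CN(C)c4ccccc4O3)cc2Cl)c1`, is obtained from compound 2 by one change: methyl in place of hydrogen on an aromatic carbon. Among the compounds with values here, no step between two measured compounds shows the effect of this particular change, so there is no directly comparable pair to lean on. Small additions of this kind elsewhere in the series, as between compound 2 and compound 3, have left the number where it was. The expected step from compound 2 to compound 4 is therefore small, a 1.3-fold higher number from compound 2 to compound 4 (0.10 log units; within the scatter), with no confident direction. Compound 4 is estimated at 20 nM, within 6 nM to 60 nM.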

Compound 4, inhibition constant: 12 nM
The estimate for compound 4 lay 1.7-fold (0.22 log units) above the measured number; the measured number falls inside the stated range.
By their numbers in this assay, from the lowest: compounds 4, 3 and 2 (each within the scatter of the next); then compound 1.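

In this assay, within the data shown here, going from 3-(carboxymethyl)phenyl to 3-(carboxymethyl)-5-methylphenyl gives a 1.3-fold lower number from compound 2 to compound 4 (0.12 log units; within the scatter), the first direct reading of this change. This aromatic carbon, meta to a carboxymethyl group and meta to a large group, therefore accepts one added methyl with no shift that can be told apart from the usual scatter. Nothing measured here offers a reason for this result.

One small group at one position says little about what larger or different groups would do on the same carbon, such as an ethyl, a methoxy or an amine. On these data alone, it also remains open whether the methyl would give the same result on a compound with a different substituent elsewhere on the shared core.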